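The compounds below may be only part of what the source reports. "The series", "measured", "known", "first", "only" and "open" are said of these compounds alone.

Three compounds share one core and differ only in the halogen carried on one aromatic ring: compound 1 `C[C@@H](NC(=O)Nc1cccc(F)c1)c1ccccc1`, compound 2 `C[C@@H](NC(=O)Nc1ccc(F)cc1)c1ccccc1` and compound 3 `C[C@@H](NC(=O)Nc1ccc(I)cc1)c1ccccc1`. In an ADME assay on the whole organism with Oryza sativa as the target, tested at 0.1 uM (a higher number here means a weaker effect of the compound at the concentration tested, a lower number a stronger effect), compound 1 gives 99%. In this assay compound 2 gives 98%, and in the same assay compound 3 gives 100%. Compound 2 stands alongside the other two, since both compound 1 and compound 3 lie within the usual scatter of it, so no order among the three can be read from these numbers. Within the data shown here, the one single-change step measured between them, iodo in place of fluoro on an aromatic carbon, gave a number 2 percentage points higher from compound 2 to compound 3 (within the scatter).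

The next compound, compound 4 `C[C@@H](NC(=O)Nc1ccc(F)c(F)c1)c1ccccc1`, arises from compound 2 by fluoro in place of hydrogen on an aromatic carbon. Among the measured compounds shown here, the only measured step that bears on this is the halogen exchange, which remained within the scatter, and all three numbers so far sit close to the top of the scale in this assay. A further halogen on the same ring is therefore not expected to produce a step beyond the scatter. For compound 4 the expected step from compound 2 is a number 1 percentage points higher from compound 2 to compound 4 (within the scatter). Compound 4 is accordingly estimated at 99%, with a range from 94% to 100%.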

Compound 4, a percentage reported as activity, at one concentration (the size of the read-out at that concentration, not a potency): 99%
Estimate against measurement, compound 4: no gap at the digits printed; measured number inside the range.
By their numbers in this assay, from the lowest: compounds 2, 1, 4 and 3 (each within the scatter of the next).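

In this assay, putting a second fluoro on an aromatic carbon ortho to a fluoro group and meta to a large group gave a number 1 percentage points higher from compound 2 to compound 4 (within the scatter). The same compound can also be reached from the other monofluoro compound, and that change gave no change at the digits printed from compound 1 to compound 4 (within the scatter). The earlier compounds had shown only one halogen exchanged for another, whereas these two steps show that adding a fluoro in place of hydrogen also stays within the scatter, whichever of the two single-fluoro compounds it is read from. No measurement is available that would account for this result.

The compounds shown leave open whether anything at this position can move the number beyond the scatter, since they carry only halogens on this ring and all four lie within the scatter of one another. On these data alone, an amine, a carboxylic acid or a methoxy group in place of the fluoro would test this, and it also remains open whether a change elsewhere on the shared core would have a larger effect.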